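The source may report more compounds than this note shows. Statements on the series, on what has been measured and on what is new or still open speak of the compounds shown alone.

Working notes on the series, read in a physicochemical assay for solubility, measured as kinetic solubility; a lower number here means a less soluble compound, a higher number a more soluble compound. Compound 1 `C[C@H](NC(=O)c1cc(C(F)(F)F)nn1C)c1nc(-c2ccnc(N(C)C)c2)no1` gives 28000 nM, compound 2 `COCc1cc(-c2noc([C@H](C)NC(=O)c3cc(C(F)(F)F)nn3C)n2)ccn1` gives 200000 nM, and compound 3 `CNc1cc(-c2noc([C@H](C)NC(=O)c3cc(C(F)(F)F)nn3C)n2)ccn1` gives 143000 nM. Compound 3 is therefore level with compound 2 within the scatter and clearly above compound 1.

The next compound is compound 4 `COC(C)(C)c1cc(-c2noc([C@H](C)NC(=O)c3cc(C(F)(F)F)nn3C)n2)ccn1`, which carries 1-methoxy-1-methylethyl in place of methylamino on an aromatic carbon. Among the measured compounds shown here, no measured step tests this group directly. Exchanging methoxymethyl for methylamino gave a 1.4-fold lower number from compound 2 to compound 3 (0.15 log units; within the scatter), so that swap did not separate the numbers. Both of these groups stand well clear of dimethylamino in compound 1, as seen in a 7.1-fold higher number from compound 1 to compound 2 (0.85 log units; beyond the scatter). The closest guide is the loss of a methyl on the nitrogen, which went with a 5.1-fold higher number from compound 1 to compound 3 (0.71 log units; beyond the scatter), and compound 4 moves the other way in size. On that reading, a modest step to a lower number is expected: a 2.9-fold lower number from compound 3 to compound 4 (0.46 log units; beyond the scatter). Compound 4 is estimated at 50000 nM, with an expected range of 18000 nM to 130000 nM.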

Compound 4, solubility: 123000 nM
Compound 4: the middle estimate sits 2.5-fold (0.39 log units) below what was measured, and the stated range covers the measured number.
By their numbers in this assay, from the lowest: compound 1; then compounds 4, 3 and 2 (each within the scatter of the next).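

At this aromatic carbon next to the ring nitrogen, 1-methoxy-1-methylethyl stays level with the two earlier groups in this assay: the reading is a 1.2-fold lower number from compound 3 to compound 4 (0.07 log units; within the scatter) and a 1.6-fold lower number from compound 2 to compound 4 (0.21 log units; within the scatter) and both steps lie within the scatter. Methylamino, methoxymethyl and 1-methoxy-1-methylethyl are therefore not separated here, even though the change from methylamino to 1-methoxy-1-methylethyl removes the hydrogen-bond donor and goes from 2 to 5 heavy atoms. Dimethylamino alone stands apart among the four, with a 4.4-fold higher number from compound 1 to compound 4 (0.64 log units; beyond the scatter) beyond the scatter, and nothing measured here gives a reason for these numbers.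

From the compounds shown here alone, a carbon-only group such as tert-butyl at this place remains open, and so does a ring amine such as morpholine. Either would show whether the low number of compound 1 extends to other amines.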